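From Methyl to Methylcarbamoyl: One Change, One Estimate

A few compounds are considered here, and "the series" means these few. Any claim that something is new, unique, unknown or untested is made for them only; others in the source may bear on it.

Compound 1, `CCOC(=O)c1cccc(-c2ccc(CN3CCCC3)cc2)c1`: > 200000 nM (a limit of the assay)
Compound 2, `CCOc1ccc(-c2cccc(C)c2)cc1`: 70000 nM

Both compounds were tested in an assay on COS-7 cells for inhibition of patatin-like phospholipase domain-containing protein 2 (Mus musculus); a lower number here means a stronger inhibitor, a higher number a weaker inhibitor. The figure for compound 1 is a limit of the assay and not a number. In this assay, within the data shown here, compound 2 gives 70000 nM, the only actual number among the two results, so compound 2 stands alone as a reference point, with the other result being (the limit of > 200000 nM in this assay, at which 1 of the 2 values shown sits).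

Compound 3, `CCOc1ccc(-c2cccc(C(=O)NC)c2)cc1`, has not yet been measured. It differs from compound 2 in a single place: methylcarbamoyl in place of methyl on an aromatic carbon. Among the measured compounds shown here, no measured pair shows this exchange, so its size cannot be read from the data. The step is expected to be a 1.2-fold lower number from compound 2 to compound 3 (0.07 log units; within the scatter), which is no farther than the usual scatter in either direction. Compound 3 is therefore expected to give about 60000 nM in this assay, with a plausible range from 15000 nM to 200000 nM.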

Compound 3, half-maximal inhibitory concentration: > 200000 nM
Compound 3: a limit, no number; the forecaster's own chance of this, stated with the estimate: 35%; at least 3.3-fold (0.52 log units) between middle value and limit.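

Methylcarbamoyl in place of methyl on this aromatic carbon brings an at least 2.8-fold higher number from compound 2 to compound 3 (0.45 log units; beyond the scatter) in this assay, so the weak but real inhibition seen with compound 2 does not survive this exchange. The entry for compound 3, > 200000 nM, is a limit of the assay and not a number. Only the lower end of the step can therefore be stated, because the true value of compound 3 lies out of reach, as it does for compound 1: the limit of > 200000 nM in this assay, at which 2 of the 3 values shown sit.

The compounds shown leave open whether the amide hydrogen or the added atoms as a whole account for this drop. Comparing a dimethylcarbamoyl group, a carboxylic acid or a primary amine at the same place would begin to separate these possibilities.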